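The source may report more compounds than this note shows. Statements on the series, on what has been measured and on what is new or still open speak of the compounds shown alone.

Working notes on the series. Compound 3 `CC(C)c1ccc(Nc2nc(SCc3cn(CC(=O)NC(=O)Nc4ccccn4)nn3)nc(-c3ccc(Cl)cc3)c2C#N)cc1` gives 16900 nM in a functional assay on MGC-803 cells (Homo sapiens) for inhibition, read by MTT assay, with a stated time of 72 h; a lower number here means a stronger inhibitor, a higher number a weaker inhibitor; against compound 2 `Cc1ccc(Nc2nc(SCc3cn(CC(=O)NC(=O)Nc4ccccn4)nn3)nc(-c3ccc(C)cc3)c2C#N)cc1` with 9890 nM the gap lies within the scatter, against compound 1 `COc1cc(-c2nc(SCc3cn(CC(=O)NC(=O)Nc4ccccn4)nn3)nc(Nc3ccc(C)cc3)c2C#N)cc(OC)c1OC` with 7030 nM it lies beyond it. Among the compounds with values here, the only measured step, a 1.4-fold higher number from compound 1 to compound 2 (0.15 log units; within the scatter), changes the aryl group, not the anilino ring, so it does not bear on the move to compound 4 `Cc1ccc(Nc2nc(SCc3cn(CC(=O)NC(=O)Nc4ccccn4)nn3)nc(-c3ccc(Cl)cc3)c2C#N)cc1`, which is methyl in place of isopropyl on an aromatic carbon. Within the data shown here, no measured pair shows this change; compound 2 and compound 4 share the 4-methylphenylamino group and differ in the aryl group, for which no step is known. Compound 4 is therefore expected near compound 3 and compound 2, with a 1.4-fold lower number from compound 3 to compound 4 (0.15 log units; within the scatter) and no step beyond the scatter. Estimate for compound 4: 12000 nM, range 6000 nM to 25000 nM.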

Compound 4, half-maximal inhibitory concentration: 24000 nM
Beside the measured number, compound 4's estimate is 2.0-fold (0.30 log units) below it, and the stated range covers the measured number.
By their numbers in this assay, from the lowest: compounds 1, 2, 3 and 4 (each within the scatter of the next, the first and the last beyond it).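

In this assay, (4-methylphenyl)amino in place of (4-isopropylphenyl)amino gives a 1.4-fold higher number from compound 3 to compound 4 (0.15 log units; within the scatter), so this position shows no readable response to shortening the group. The aryl group, which gave no readable change earlier, now matters: chloro in place of methyl gives a 2.4-fold higher number from compound 2 to compound 4 (0.39 log units; beyond the scatter), and 4-chlorophenyl in place of 3,4,5-trimethoxyphenyl gives a 3.4-fold higher number from compound 1 to compound 4 (0.53 log units; beyond the scatter). No measurement offers an explanation for these steps. Still open, from the compounds shown here alone, is whether an amine or a carboxylic acid in place of methyl on that aromatic carbon would shift the number beyond the scatter.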